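The source may hold more compounds than are shown below. What is called first, only, known or untested is meant among the compounds shown, and "the series" means these compounds.

Working notes on the series built on the shared core of compound 1 `O=C(NCN1CCC(c2cccc[n+]2[O-])CC1)c1ccccc1`. In a functional assay on HEK293 cells for agonist activity at D(4) dopamine receptor (Homo sapiens), read by FLIPR (on this read-out lower numbers stand for an effect already at smaller amounts and higher numbers for an effect only at larger amounts of compound), compound 1 gives 532 nM. Compound 2 `O=C(NCN1CCC(c2cccc[n+]2[O-])CC1)c1cnccc1Cl` gives 1290 nM in this assay, and compound 3 `N#Cc1cccc(C(=O)NCN2CCC(c3cccc[n+]3[O-])CC2)c1` gives 840 nM. Among these three numbers compound 3 stands second highest: the step of a 1.5-fold lower number from compound 2 to compound 3 (0.19 log units; within the scatter) and the step of a 1.6-fold higher number from compound 1 to compound 3 (0.20 log units; within the scatter) are both inside the usual scatter, so no order among the three can be read from the numbers.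

Compound 4 `O=C(NCN1CCC(c2cccc[n+]2[O-])CC1)c1ccccn1` is not yet measured. The change from compound 3 is pyridin-2-yl in place of 3-cyanophenyl on a carbonyl carbon. Among the compounds with values here, two measured steps bear on it: the swap of the aryl group on the carbonyl carbon in a 2.4-fold higher number from compound 1 to compound 2 (0.38 log units; beyond the scatter) was modest and beyond the scatter, while a 1.6-fold higher number from compound 1 to compound 3 (0.20 log units; within the scatter) stayed within it. On that basis the expected step is a 1.3-fold lower number from compound 3 to compound 4 (0.11 log units; within the scatter), within the scatter, because compound 1 at 532 nM and compound 3 sit so close. Compound 4 is therefore estimated at 650 nM in this assay, with a range from 250 nM to 1700 nM.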

Compound 4, half-maximal effective concentration: 3150 nM
Compound 4: middle estimate off by 4.8-fold (0.69 log units), on the low side, outside the stated range (above it).
By their numbers in this assay, from the lowest: compounds 1, 3 and 2 (each within the scatter of the next, the first and the last beyond it); then compound 4.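

In this assay, pyridin-2-yl on the carbonyl carbon gives the highest number of the four, with a 5.9-fold higher number from compound 1 to compound 4 (0.77 log units; beyond the scatter), a 2.4-fold higher number from compound 2 to compound 4 (0.39 log units; beyond the scatter) and a 3.8-fold higher number from compound 3 to compound 4 (0.57 log units; beyond the scatter), all beyond the scatter. Within the data shown here, the position therefore answers to the choice of aryl group over a wider span than the earlier compounds showed, where the largest step was a 2.4-fold higher number from compound 1 to compound 2 (0.38 log units; beyond the scatter). Compound 2 and compound 4 both carry a six-membered aromatic ring with a hetero atom yet still stand apart, so that feature alone does not set the number.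

No measurement at hand accounts for this rise. The compounds shown leave open how an amine or a carboxylic acid on the phenyl group would read here, and whether the steps at this position hold with any other core.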